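Methyl to ethyl on the guanidine-type hydrazone series

This account rests on a few compounds, and the source may have more. Where it says the series, first, only, none or still open, it means among the compounds named here.

Of the compounds shown here, two have been measured so far in a functional assay on T-24 cells (Homo sapiens) for antiproliferative activity; on this read-out higher numbers stand for weaker inhibition and lower numbers for stronger inhibition. Compound 1 `N=C(N)N/N=C/c1cccc(C(N)=O)c1` returned only a limit, > 184000 nM, and not a number. For the measured compounds named here, compound 2 `C/C(=N\N=C(N)N)c1cccc(C(=N)N)c1` gives 118000 nM, the only actual number so far.

The next compound is compound 3 `CC/C(=N\N=C(N)N)c1cccc(C(=N)N)c1`. It differs from compound 2 by methyl in place of hydrogen on a saturated chain carbon bound to a carbon with a double bond to nitrogen, which turns methyl into ethyl. Going by the values given here, no measured pair shows what such a change does in this assay. The expected size of the step of a 1.2-fold lower number from compound 2 to compound 3 (0.07 log units; within the scatter) is nothing beyond the usual scatter, in either direction. That expectation rests on compound 2 alone, at 118000 nM, and so stays wide. Compound 3 is estimated at 100000 nM, with an expected range from 40000 nM to 220000 nM.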

Compound 3, half-maximal inhibitory concentration: > 152000 nM
Compound 3: only a limit was reported (the forecaster's own chance of this, stated with the estimate: 20%); at least 1.5-fold (0.18 log units) between middle value and limit.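

In this assay, for the compounds shown here, the change from methyl to ethyl at this place gives the only step available so far, an at least 1.2-fold higher number from compound 2 to compound 3 (0.10 log units; that floor lies within the scatter). Compound 3 is reported only as a limit, so this step is a floor and not a measured size: the limit of > 152000 nM in this assay, at which 1 of the 3 values shown sits. Going by these compounds alone, the floor lies within the scatter, so the data do not separate compound 3 from compound 2, and compound 2 remains the only compound with an actual number.

From the compounds shown here alone, whether a propyl chain or a hydroxymethyl group on this saturated chain carbon would return an actual number in this assay remains open. Going by these compounds, the true size of the step to compound 3 also remains open, and with it whether ethyl differs from methyl here at all.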